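Benzyl substituent changes on the brominated acrylamide thiazolidinedione series

This account rests on a few compounds, and the source may have more. Where it says the series, first, only, none or still open, it means among the compounds named here.

Measured so far in a functional assay on L1210 cells (Mus musculus) for cytotoxicity, read by cell counting, with a stated time of 2 days; on this read-out lower numbers stand for stronger inhibition and higher numbers for weaker inhibition:
- compound 1, `C=C(Br)C(=O)Nc1cccc(/C=C2\SC(=O)N(Cc3ccc(Cl)cc3)C2=O)c1`: 940 nM
- compound 2, `C=C(Br)C(=O)Nc1cccc(/C=C2\SC(=O)N(Cc3ccc(C)cc3)C2=O)c1`: 600 nM
- compound 3, `C=C(Br)C(=O)Nc1ccc(/C=C2\SC(=O)N(Cc3cccc(F)c3)C2=O)cc1`: 1200 nM

Going by the values given here, compound 2 gives the lowest of the three numbers in this assay, but the only measured step among them is a 1.6-fold lower number from compound 1 to compound 2 (0.19 log units; within the scatter) and lies within the scatter, and compound 3 also sits within the scatter of compound 2. No ordering can be read from these three values.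

The next compound, compound 4, `C=C(Br)C(=O)Nc1cccc(/C=C2\SC(=O)N(Cc3cccc(Cl)c3)C2=O)c1`, is made from compound 2 by the change (3-chlorophenyl in place of 4-methylphenyl on a saturated chain carbon bound to an amide-type nitrogen in a ring).

Among the compounds with values here, only one measured step bears on this change: the methyl-for-chloro swap on the benzyl ring, a 1.6-fold lower number from compound 1 to compound 2 (0.19 log units; within the scatter), which was within the scatter. Within the data shown here, compound 3 carries a fluorine on the benzyl ring but also differs from compound 2 in where the acrylamide-bearing ring is attached, so it gives no clean step; its value and that of compound 2 simply lie within the scatter of each other. Chloro in place of methyl, now moved to a different position on the benzyl ring, is therefore expected to shift this assay little, with perhaps a small rise in the number because the reverse swap gave a 1.6-fold lower number from compound 1 to compound 2 (0.19 log units; within the scatter).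

Compound 4 is expected at 850 nM, in a range of 400 nM to 1800 nM, corresponding to an estimated step of a 1.4-fold higher number from compound 2 to compound 4 (0.15 log units; within the scatter).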

Compound 4, half-maximal inhibitory concentration: 1100 nM
The estimate for compound 4 lay 1.3-fold (0.11 log units) below the measured number; the measured number falls inside the stated range.
By their numbers in this assay, from the lowest: compounds 2, 1, 4 and 3 (each within the scatter of the next).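

Working notes on the substituted benzyl group on the ring nitrogen: in this assay the step of a 1.8-fold higher number from compound 2 to compound 4 (0.26 log units; within the scatter) covers 3-chlorophenyl in place of 4-methylphenyl, and the step of a 1.2-fold higher number from compound 1 to compound 4 (0.07 log units; within the scatter) gives the first read on where the chlorine sits, with 3-chlorophenyl in place of 4-chlorophenyl. Both steps lie within the scatter, so at this place on the shared core neither the exchange of methyl for chloro nor the change of chlorine position separates compounds 1, 2 and 4, and no ordering among these three can be drawn. No measured evidence bears on this result.

Going by these compounds alone, compound 3 differs from each of the others in more than one place, so no step to it can be read, and the effect of where the acrylamide-bearing ring is attached stays open. Also open, on these data alone, is whether a carboxylic acid or an amine on the benzyl ring, or a longer chain in place of the benzyl group, would move the number in this assay beyond the scatter.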